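Long-chain series: moving from a saturated to an unsaturated chain

This account rests on a few compounds, and the source may have more. Where it says the series, first, only, none or still open, it means among the compounds named here.

Within the data shown here, compound 2 `CCCCCCCCCCCCCCCCCC1=C(C(=O)OC)C(c2cccc(O)c2)NC(=S)N1` holds the highest of the two numbers available so far in a functional assay on C6 cells (Rattus norvegicus) for cytotoxicity, read by MTT assay, with a stated time of 48 h (on this read-out lower numbers stand for stronger inhibition and higher numbers for weaker inhibition), where compound 2 gives 6850 nM. Among the measured compounds shown here, its nearest neighbour is compound 1 `CCCCCCCCCCCCCCCC1=C(C(=O)OC)C(c2cccc(O)c2)NC(=S)N1`; in this assay compound 1 gives 5110 nM, and the only measured step, a 1.3-fold higher number from compound 1 to compound 2 (0.13 log units; within the scatter), stays within the scatter. Compound 3 `CCCCCCCC/C=C\CCCCCCCC1=C(C(=O)OC)C(c2cccc(O)c2)NC(=S)N1` differs from compound 2 by dec-1-en-1-yl in place of decyl on a saturated chain carbon, seven bonds along the chain from a double-bonded ring carbon. For the measured compounds named here, no measured step involves a double bond within the chain, so nothing directly bears on this change. Going by the values given here, the one step available, a 1.3-fold higher number from compound 1 to compound 2 (0.13 log units; within the scatter), shows that altering the far part of the saturated chain left the number within the scatter, and a change confined to the same region of the chain is expected to do little as well. The expected step is a 1.1-fold lower number from compound 2 to compound 3 (0.06 log units; within the scatter), with no direction beyond the scatter. For compound 3 the estimate in this assay is 6000 nM, with a range from 2500 nM to 15000 nM.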

Compound 3, half-maximal inhibitory concentration: 38400 nM
Compound 3: middle estimate off by 6.4-fold (0.81 log units), on the low side, and the stated range ends below it.
By their numbers in this assay, from the lowest: compounds 1 and 2 (each within the scatter of the next); then compound 3.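

In this assay, this part of the chain proves sensitive to the change: dec-1-en-1-yl in place of decyl, on a saturated chain carbon seven bonds along the chain from a double-bonded ring carbon, gives a 5.6-fold higher number from compound 2 to compound 3 (0.75 log units; beyond the scatter), beyond the scatter, whereas the saturated pair stayed within it. Against the shorter saturated chain, dec-1-en-1-yl in place of octyl gives a 7.5-fold higher number from compound 1 to compound 3 (0.88 log units; beyond the scatter), so the unsaturated compound stands apart from both saturated ones, a reading that rests on this single unsaturated compound. The data shown offer no measurement that would account for this shift.

Going by these compounds, whether the shift follows from the double bond itself, its geometry or its place in the chain remains open. Also open, on these data alone, is how a chain carrying an alkyne, or two double bonds, would read here.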